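The source may report more compounds than this note shows. Statements on the series, on what has been measured and on what is new or still open speak of the compounds shown alone.

Compound 1 `CC(=O)N1CCC(C(=O)N2C[C@@H](O[C@H](C)c3cc(C(F)(F)F)cc(C(F)(F)F)c3)[C@H](c3ccc(F)cc3)C2)CC1`: in an assay on CHO cells for displacement of a labelled ligand from Substance-P receptor (Homo sapiens) (on this read-out higher numbers stand for weaker inhibition and lower numbers for stronger inhibition), compound 1 gives 0.07 nM.
Compound 2 `C[C@@H](O[C@@H]1CN(C(=O)NC(C)(C)C)C[C@H]1c1ccc(F)cc1)c1cc(C(F)(F)F)cc(C(F)(F)F)c1`: in this assay compound 2 gives 0.14 nM.

On the numbers shown, compound 2 sits so close to compound 1 that the step of a 2.0-fold higher number from compound 1 to compound 2 (0.30 log units; within the scatter) cannot separate them; neither can be called the stronger. That step exchanged one group on a carbonyl carbon, while the carbonyl on the amine nitrogen in the ring was kept in both compounds. Compound 3 `CC1=C(N2C[C@@H](O[C@H](C)c3cc(C(F)(F)F)cc(C(F)(F)F)c3)[C@H](c3ccc(F)cc3)C2)CCC1=O` has not yet been measured. It differs from compound 2 by 2-methyl-3-oxocyclopent-1-en-1-yl in place of (tert-butyl)carbamoyl on an amine nitrogen in a ring. Going by the values given here, no measured step bears directly on this change: the only step seen left the carbonyl on that ring nitrogen in place, whereas here the carbonyl is lost and a ring takes its place. The outcome in this assay is therefore uncertain, and a modestly weaker result is estimated, a 2.5-fold higher number from compound 2 to compound 3 (0.40 log units; beyond the scatter). For compound 3 the estimated value is 0.35 nM, with a range from 0.06 nM to 2.5 nM.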

Compound 3, half-maximal inhibitory concentration: 0.13 nM
The estimate for compound 3 lay 2.7-fold (0.43 log units) above the measured number; the measured number falls inside the stated range.
By their numbers in this assay, from the lowest: compounds 1, 3 and 2 (each within the scatter of the next).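

Compound 1 and compound 2 both carry a carbonyl on the amine nitrogen in the ring, so they could not show whether that carbonyl matters. In this assay the step of a 1.1-fold lower number from compound 2 to compound 3 (0.03 log units; within the scatter) removes that carbonyl and the hydrogen-bond donor of the (tert-butyl)carbamoyl group and brings in a five-membered ring of carbon only, yet the two numbers cannot be told apart. The step of a 1.9-fold higher number from compound 1 to compound 3 (0.27 log units; within the scatter) reads the same way, so across these three compounds this position accepts a group without a carbonyl on the nitrogen and still gives sub-nanomolar-range numbers of the same order.

On these data alone, whether a simple amine or a carboxylic acid placed on that ring nitrogen would also fit remains open. Nothing measured here explains why these different groups read alike.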